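This account rests on a few compounds, and the source may have more. Where it says the series, first, only, none or still open, it means among the compounds named here.

Measured compounds:
- compound 1 `Nc1ccnc(-c2nn(Cc3ccccc3F)c3ncccc23)n1`: 270 nM; 265000 nM (2 entries)
- compound 2 `CCc1cnc(-c2nn(Cc3ccccc3F)c3ncccc23)nc1N`: 272000 nM
- compound 3 `CC(C)(C)c1cnc(-c2nn(Cc3ccccc3F)c3ncccc23)nc1N`: 709000 nM

In a functional assay (aorta) with Oryctolagus cuniculus as the target (a lower number here means a stronger inhibitor, a higher number a weaker inhibitor), compound 3 stands highest of the two single numbers, with compound 2 nearest; the step of a 2.6-fold higher number from compound 2 to compound 3 (0.42 log units; beyond the scatter) is modest but beyond the scatter. Compound 1 has two entries in this assay that lie far apart (the several entries of compound 1 in this assay, 270 nM; 265000 nM (2 entries)), so it gives no single number and offers no anchor for comparison.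

Compound 4 `CCCCCCc1cnc(-c2nn(Cc3ccccc3F)c3ncccc23)nc1N` differs from compound 3 by one change: hexyl in place of tert-butyl on an aromatic carbon. Among the compounds with values here, the only measured step that bears on it is the one from an ethyl to a tert-butyl at the same aromatic carbon, a 2.6-fold higher number from compound 2 to compound 3 (0.42 log units; beyond the scatter), where the larger group gave the higher number. A hexyl is again a larger substituent than the tert-butyl it replaces, so a further rise of similar size is the plain reading, though with a single step there is no way to tell whether a longer chain behaves like a bulkier one.

For compound 4 the expected step is a 1.4-fold higher number from compound 3 to compound 4 (0.15 log units; within the scatter), a modest rise. Compound 4 is therefore estimated at 1000000 nM in this assay, with a range from 300000 nM to 3000000 nM.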

Compound 4, half-maximal inhibitory concentration: 1040000 nM
Compound 4: the middle estimate sits 1.0-fold (0.02 log units) below what was measured; the measured number falls inside the stated range.
By their numbers in this assay, from the lowest: compound 2; then compounds 3 and 4 (each within the scatter of the next).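

In this assay the change from tert-butyl to hexyl gives a 1.5-fold higher number from compound 3 to compound 4 (0.17 log units; within the scatter), so at this position, ortho to an amino group, the branched group and the straight chain cannot be told apart. Measured from ethyl, the hexyl chain gives a 3.8-fold higher number from compound 2 to compound 4 (0.58 log units; beyond the scatter) and the tert-butyl group gives a 2.6-fold higher number from compound 2 to compound 3 (0.42 log units; beyond the scatter), so the numbers of both larger groups stand above that of the ethyl compound, while the series offers no separation between the two larger groups themselves. Nothing in the data shown speaks to why these groups read as they do.

As far as these compounds go, the size of the step from hydrogen to any of these groups stays open, since compound 1, which carries hydrogen at this position, gives no single reference number: the several entries of compound 1 in this assay, 270 nM; 265000 nM (2 entries). Also open, from the compounds shown here alone, is whether the numbers at this position stay level with a longer chain than hexyl, and how a group of a different kind, such as an amine or a carboxylic acid at the end of the chain, would read in this assay.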